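Hydroxy for Chloro on a Weakly Cytotoxic Core

The source may report more compounds than this note shows. Statements on the series, on what has been measured and on what is new or still open speak of the compounds shown alone.

compound 1 `COc1cc(-c2nnc3n2NC(c2ccco2)C(C(=O)c2ccc(Cl)cc2)S3)cc(OC)c1OC`: 67800 nM
compound 2 `COc1cc(C(=O)C2Sc3nnc(-c4cc(OC)c(OC)c(OC)c4)n3NC2c2cccs2)cc(OC)c1OC`: > 100000 nM

Of the compounds shown here, two have so far been tested in a functional assay on PC-3 cells (Homo sapiens) for cytotoxicity, read by MTT assay, with a stated time of 48 h; a higher number here means a weaker inhibitor, a lower number a stronger inhibitor. Within the data shown here, compound 1 `COc1cc(-c2nnc3n2NC(c2ccco2)C(C(=O)c2ccc(Cl)cc2)S3)cc(OC)c1OC` gives 67800 nM in this assay, and this is the only actual number obtained. Compound 2 `COc1cc(C(=O)C2Sc3nnc(-c4cc(OC)c(OC)c(OC)c4)n3NC2c2cccs2)cc(OC)c1OC` reaches only the limit of this assay, reported as > 100000 nM, which is a limit rather than a measured number (the limit of > 100000 nM in this assay, at which 1 of the 2 values shown sits). Among the measured compounds shown here, compound 1 therefore stands as the single measured value, with nothing else to rank it against.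

Compound 3 `COc1cc(-c2nnc3n2NC(c2ccco2)C(C(=O)c2ccc(O)cc2)S3)cc(OC)c1OC` differs from compound 1 by hydroxy in place of chloro on an aromatic carbon. For the measured compounds named here, no measured pair shows this same change, so its size cannot be taken from the data. The step of a 1.2-fold higher number from compound 1 to compound 3 (0.07 log units; within the scatter) is expected to be small, no larger than the usual scatter or leaning slightly toward weaker inhibition. Compound 3 is accordingly expected to give about 80000 nM, within a range from 25000 nM to 250000 nM, with a real chance that only a limit is reported.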

Compound 3, half-maximal inhibitory concentration: 38300 nM
The estimate for compound 3 lay 2.1-fold (0.32 log units) above the measured number; the range from low to high includes it.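

Among these compounds, this is the first pair on the shared core that differs in one place, and in this assay it gives a 1.8-fold lower number from compound 1 to compound 3 (0.25 log units; within the scatter). At this place, on an aromatic carbon of the six-membered aromatic ring of carbon only and para to a large group, 4-chlorophenyl and 4-hydroxyphenyl therefore cannot be told apart, even though the hydroxy brings a hydrogen-bond donor and a hydrogen-bond acceptor that the chloro lacks, and both compounds give actual numbers rather than a limit. Nothing measured here offers a reason for this outcome.

On these data alone, whether an amine, a methoxy or a carboxylic acid at this same place would shift the number beyond the scatter remains open. Among the compounds shown here, this is also the only pair showing hydroxy in place of chloro, so whether the change behaves alike on any other core remains open too.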